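A few compounds are considered here, and "the series" means these few. Any claim that something is new, unique, unknown or untested is made for them only; others in the source may bear on it.

Measured so far:
compound 1, `C=CCNC(=O)/C(C)=C(\C)c1ccc(C)cc1`, in a toxicity assay on the whole organism (strain Icem-CET (SPF Caw)) for cytotoxicity, with Mus musculus as the target (a lower number here means that less compound is needed, a higher number that more compound is needed for the effect), gives 150 mg/kg;
compound 2, `C/C(C(=O)NC1CC1)=C(/C)c1ccc(Cl)cc1`, gives 150 mg/kg;
compound 3, `C/C(C(=O)NC1CC1)=C(/C)c1ccc(C)cc1`, gives 150 mg/kg.

All three share one core and differ only at two places. The step of no change at the digits printed from compound 3 to compound 1 (within the scatter) belongs to the change (allyl in place of cyclopropyl on an amide-type nitrogen); the step of no change at the digits printed from compound 2 to compound 3 (within the scatter) belongs to the change (chloro in place of methyl on an aromatic carbon), read the other way round. Neither exchange moved the read-out beyond the usual scatter, so the three values stand level with one another.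

Compound 4, `C=CCNC(=O)/C(C)=C(\C)c1ccc(Cl)cc1`, has not yet been measured in this assay. Within the data shown here, it differs from compound 2 by allyl in place of cyclopropyl on an amide-type nitrogen, which is the same change as the one from compound 3 to compound 1, on the same kind of amide-type nitrogen with the same neighbour. That earlier step no change at the digits printed from compound 3 to compound 1 (within the scatter) left the dose unchanged within the scatter, so the step of no change at the digits printed from compound 2 to compound 4 (within the scatter) is expected to be of the same small size. The expectation for compound 4 is therefore 150 mg/kg, with a likely span from 75 mg/kg to 300 mg/kg.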

Compound 4, dose for half-maximal effect: 70 mg/kg
Compound 4: the middle estimate sits 2.1-fold (0.33 log units) above what was measured, and the stated range ends above it.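

For allyl in place of cyclopropyl on the amide-type nitrogen in this assay, the chloro-bearing pair gives a 2.1-fold lower number from compound 2 to compound 4 (0.33 log units; beyond the scatter), and set beside the methyl-bearing pair this shows no real disagreement: the same change on two cores in this assay, no change at the digits printed (within the scatter) from compound 3 to compound 1 and a 2.1-fold lower number (0.33 log units; beyond the scatter) from compound 2 to compound 4, 2.1-fold (0.33 log units) apart, within the scatter of two such steps. For chloro in place of methyl on the aromatic carbon, the allyl-bearing pair gives a 2.1-fold lower number from compound 1 to compound 4 (0.33 log units; beyond the scatter), and set beside the cyclopropyl-bearing pair this again shows no real disagreement: the same change on two cores in this assay, no change at the digits printed (within the scatter) from compound 2 to compound 3 and a 2.1-fold higher number (0.33 log units; beyond the scatter) from compound 4 to compound 1, 2.1-fold (0.33 log units) apart, within the scatter of two such steps. Each change therefore carries from one core to the other without a gap beyond the scatter, but one pair of steps per change cannot show whether the lower number of compound 4 is a lasting effect of combining allyl with chloro.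

The compounds shown leave open whether that combination holds with other groups, such as a longer chain like butyl on the amide-type nitrogen or methoxy on the aromatic carbon. They also leave open how a hydroxyl or an amine at either place would compare.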